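Carboxy in place of sulfamoyl: compound 2 to compound 3

The source may report more compounds than this note shows. Statements on the series, on what has been measured and on what is new or still open speak of the compounds shown alone.

Measured so far:
compound 1, `NS(=O)(=O)c1ccc(COc2ccc(CNC(=O)[C@@H]3CCC(=O)N3Cc3ccccc3)cc2)cc1`, > 5000 nM
compound 2, `NS(=O)(=O)c1ccc(COc2ccc(CNC(=O)[C@@H]3CCC(=O)N3Cc3ccc(C(F)(F)F)cc3)cc2)cc1`, > 5000 nM

In an assay on HEK293 cells for inhibition of Ataxin-2 (Mus musculus), read by fluorescence and Amplex Red (on this read-out lower numbers stand for stronger inhibition and higher numbers for weaker inhibition), compound 1 gives > 5000 nM, which is a limit of the assay and not a number. Compound 2 gives > 5000 nM in this assay, again only a limit. Within the data shown here, the single measured step, a step that the two limits leave unreadable from compound 1 to compound 2, therefore cannot be read. Compound 2 stands at the limit of > 5000 nM in this assay, at which 2 of the 2 values shown sit; nothing places it more exactly than that.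

Compound 3 is `O=C(O)c1ccc(COc2ccc(CNC(=O)[C@@H]3CCC(=O)N3Cc3ccc(C(F)(F)F)cc3)cc2)cc1`. It differs from compound 2 in one place: carboxy in place of sulfamoyl on an aromatic carbon.

Among the measured compounds shown here, no measured step touches this part of the structure, and the one step that is measured is unreadable, so there is nothing to scale the expected change by. For the measured compounds named here, the only footing is that compound 2 sits at the limit; the step is expected to be a step that the limit leaves unreadable from compound 2 to compound 3, with no readable size. The expectation is that compound 3 will again fall at or beyond the limit, estimated at 8000 nM with a range from 2000 nM to 40000 nM, and most likely reported as a limit.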

Compound 3, half-maximal inhibitory concentration: > 5000 nM
Compound 3 gave a limit, no number; the forecaster's own chance of this, stated with the estimate: 80%; the middle value does not contradict the limit.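

In this assay compound 3 gives > 5000 nM, a limit of the assay and not a number. The step from compound 2 to compound 3 therefore cannot be read, and the series offers only this: the limit of > 5000 nM in this assay, at which 3 of the 3 values shown sit.

The compounds shown leave open whether carboxy in place of sulfamoyl changes inhibition at all, and which compound on this shared core would give a measurable value.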